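Aryl swap from compound 1 to compound 4

The source may hold more compounds than are shown below. What is called first, only, known or untested is meant among the compounds shown, and "the series" means these compounds.

In an ADME assay on A549 cells (Homo sapiens) for cytotoxicity, read by MTT assay, with a stated time of 72 h (a lower number here means a stronger inhibitor, a higher number a weaker inhibitor), compound 1 `Brc1ccccc1-c1nnc(-c2ccc(-n3cccc3)cc2)o1` gives 252000 nM and compound 2 `O=C(NNC(=O)c1ccc(-n2cccc2)cc1)c1ccc(Br)cc1` gives 201000 nM while compound 3 `O=[N+]([O-])c1ccccc1-c1nnc(-c2ccc(-n3cccc3)cc2)o1` gives 267000 nM with no gap beyond the scatter, so compound 1 stands level with both. Compound 4 `Clc1ccc(-c2nnc(-c3ccc(-n4cccc4)cc3)o2)cc1` carries the change 4-chlorophenyl in place of 2-bromophenyl on an aromatic carbon with 4-chlorophenyl in place of 2-bromophenyl on an aromatic carbon. Going by the values given here, the one measured step that bears on this a 1.1-fold higher number from compound 1 to compound 3 (0.03 log units; within the scatter) stays within the scatter. Among the compounds with values here, no measured step covers a 4-chlorophenyl group, so this guide is thin. In this assay the estimated step of a 1.1-fold lower number from compound 1 to compound 4 (0.02 log units; within the scatter) is expected to stay within the scatter. The estimate for compound 4 is 240000 nM with an expected range of 120000 nM to 450000 nM for now.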

Compound 4, half-maximal inhibitory concentration: 256000 nM
For compound 4 the middle estimate is 1.1-fold (0.03 log units) below the measured one; the range from low to high includes it.
By their numbers in this assay, from the lowest: compounds 2, 1, 4 and 3 (each within the scatter of the next).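

In this assay the aryl group at this carbon of the oxygen-and-nitrogen ring takes 4-chlorophenyl in place of 2-bromophenyl, changing both the halogen and its ring site, and the result is a 1.0-fold higher number from compound 1 to compound 4 (0.01 log units; within the scatter). So this place now shows a second replacement, after the nitro step, with no gap beyond the scatter. Nothing available speaks to the reason for this. As far as these compounds go, whether an amine, a carboxylic acid or a longer chain at this carbon would shift the number remains open. From the compounds shown here alone, the separate contributions of halogen identity and ring site also remain open.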